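The source may hold more compounds than are shown below. What is called first, only, known or untested is meant among the compounds shown, and "the series" means these compounds.

Measured so far:
compound 1 `OC[C@@]12C[C@@H]1[C@@H](n1cnc3c(NC(C4CCC4)C4CCC4)nc(Cl)nc31)[C@H](O)[C@@H]2O` — in an ADME assay on Vero 76 cells (Chlorocebus sabaeus) for cytotoxicity, read by microscopy (a higher number here means that more compound is tolerated, a lower number that less compound is tolerated), compound 1 gives 50000 nM
compound 2 `CSc1nc(N[C@@H](C2CC2)C(C)(C)O)c2ccn([C@H]3[C@H](O)[C@H](O)[C@]4(CO)C[C@H]34)c2n1` — compound 2 gives > 100000 nM
compound 3 `CC(C)[C@@H](Nc1nc(Cl)nc2c1ncn2[C@H]1[C@H](O)[C@H](O)[C@]2(CN=[N+]=[N-])C[C@H]12)C1CC1` — compound 3 gives 32000 nM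

All three share a core that carries a ring-fused sugar-like portion and a branched amine side chain. Compound 2 stands apart in how its number reads. The value for compound 2 is a limit of the assay and not a number, as shown by the limit of > 100000 nM in this assay, at which 1 of the 3 values shown sits. So for compound 2 it is only known that the cells tolerated at least as much as the assay could test; how much more is unknown.

Compound 4 `CC(C)(O)[C@@H](Nc1nc(Cl)nc2c1ccn2[C@H]1[C@H](O)[C@H](O)[C@]2(CO)C[C@H]12)C1CC1` is compound 2 with one change: chloro in place of methylsulfanyl on an aromatic carbon. For the measured compounds named here, no measured pair shows this exact swap, so the size of the step can only be judged from the neighbours. Compound 1 and compound 3 both carry a chloro group on their core and give numbers rather than limits, with compound 1 giving 50000 nM and compound 3 giving 32000 nM. A modest step from compound 2 to compound 4 toward less tolerated is therefore expected, an at least 1.8-fold lower number from compound 2 to compound 4 (0.25 log units; that floor lies within the scatter), but one that may still fall within the scatter. Compound 4 is estimated at 55000 nM, with a range from 22000 nM to 130000 nM.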

Compound 4, half-maximal cytotoxic concentration: > 100000 nM
Compound 4 gave a limit, no number (the forecaster's own chance of this, stated with the estimate: 30%); middle value at least 1.8-fold (0.25 log units) away from the limit.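

No step can be read between compound 2 and compound 4, because each gives a limit of the assay and not a number: the limit of > 100000 nM in this assay, at which 2 of the 4 values shown sit.

The compounds shown leave open how much of either compound the cells would tolerate, and whether chloro in place of methylsulfanyl changes the tolerated amount at all.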